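Notes on 3-chlorophenyl in place of 2-chlorophenyl

This account rests on a few compounds, and the source may have more. Where it says the series, first, only, none or still open, it means among the compounds named here.

The three measured compounds share one core and differ in the aromatic group on a carbon with a double bond to nitrogen. In a functional assay on OVCAR-3 cells (Homo sapiens) for cytotoxicity, read by sulforhodamine B assay (on this read-out lower numbers stand for stronger inhibition of growth and higher numbers for weaker inhibition of growth), compound 1 (`CC1=CC[C@@H]([C@@](C)(O)CCCC(C)(C)NC(=S)N/N=C\c2ccc(C)cc2)CC1`) gives 11800 nM. Compound 2 (`CC1=CC[C@@H]([C@@](C)(O)CCCC(C)(C)NC(=S)N/N=C\c2ccc([N+](=O)[O-])cc2)CC1`) gives 88600 nM, and nitro in place of methyl on an aromatic carbon amounts to a 7.5-fold higher number from compound 1 to compound 2 (0.88 log units; beyond the scatter).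

Compound 3 (`CC1=CC[C@@H]([C@@](C)(O)CCCC(C)(C)NC(=S)N/N=C\c2ccccc2Cl)CC1`) is known only as a limit, > 100000 nM, and not as a number. Its 2-chlorophenyl in place of 4-methylphenyl amounts to an at least 8.4-fold higher number from compound 1 to compound 3 (0.92 log units; beyond the scatter). Its 2-chlorophenyl in place of 4-nitrophenyl amounts to an at least 1.1-fold higher number from compound 2 to compound 3 (0.05 log units; that floor lies within the scatter), a floor within the scatter.

Compound 4 (`CC1=CC[C@@H]([C@@](C)(O)CCCC(C)(C)NC(=S)N/N=C\c2cccc(Cl)c2)CC1`) carries 3-chlorophenyl in place of 2-chlorophenyl on a carbon with a double bond to nitrogen. Going by the values given here, no measured step tests this exact change. The nearest guides are the changes at the same place, an at least 8.4-fold higher number from compound 1 to compound 3 (0.92 log units; beyond the scatter) and an at least 1.1-fold higher number from compound 2 to compound 3 (0.05 log units; that floor lies within the scatter), together with a 7.5-fold higher number from compound 1 to compound 2 (0.88 log units; beyond the scatter) on the same aromatic group. These suggest a modest step at most, towards a lower number in this assay, with the size left open by the limit on compound 3.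

The expected step is an at least 2.5-fold lower number from compound 3 to compound 4 (0.39 log units; beyond the scatter). For compound 4 the estimated value is 40000 nM, with an expected range of 12000 nM to 100000 nM.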

Compound 4, concentration for total growth inhibition: 26500 nM
Compound 4: middle estimate off by 1.5-fold (0.18 log units), on the high side; the measured number falls inside the stated range.
By their numbers in this assay, from the lowest: compound 1; then compound 4; then compound 2. At a limit, above all of these: compound 3.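

In this assay, 3-chlorophenyl in place of 2-chlorophenyl gives an at least 3.7-fold lower number from compound 3 to compound 4 (0.57 log units; beyond the scatter), so on this carbon the difference between two groups of the same atoms is enough to separate compound 3 from compound 4. That step is a floor and not a size, since compound 3 is known only through a limit of the assay: the limit of > 100000 nM in this assay, at which 1 of the 4 values shown sits.

Against the other aromatic groups, 3-chlorophenyl in place of 4-nitrophenyl gives a 3.3-fold lower number from compound 2 to compound 4 (0.52 log units; beyond the scatter) and 3-chlorophenyl in place of 4-methylphenyl gives a 2.2-fold higher number from compound 1 to compound 4 (0.35 log units; beyond the scatter), so a chlorophenyl group at this place can give a number that lies between those of the 4-methylphenyl and 4-nitrophenyl compounds, rather than only a limit.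

The kind of group and its place on the ring still change together in these comparisons, so the two cannot be separated for methyl, nitro or chlorine. Going by these compounds, how 4-chlorophenyl, 3-methylphenyl or a phenyl ring carrying an amine would stand against compound 1 and compound 4 remains open.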